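Methylsulfanyl for methylamino on a thienyl nucleoside core

The source may report more compounds than this note shows. Statements on the series, on what has been measured and on what is new or still open speak of the compounds shown alone.

Compound 1 `CSc1ncnc2c1c(-c1ccccc1)cn2[C@@H]1O[C@H](CO)[C@@H](O)[C@H]1O` gives > 100000 nM in an ADME assay on MRC5 cells (Homo sapiens), read by MTT assay, with a stated time of 72 h; on this read-out lower numbers stand for stronger inhibition and higher numbers for weaker inhibition.
Compound 2 `COc1ncnc2c1c(-c1cccs1)cn2[C@@H]1O[C@H](CO)[C@@H](O)[C@H]1O` gives 43200 nM.
Compound 3 `CNc1ncnc2c1c(-c1cccs1)cn2[C@@H]1O[C@H](CO)[C@@H](O)[C@H]1O` gives > 100000 nM.

Compound 3 stands at a limit of this assay, not at a number. Compound 1 also stands at a limit. Within the data shown here, compound 2 is the only compound with a number, and the one step involving compound 3, an at least 2.3-fold higher number from compound 2 to compound 3 (0.36 log units; beyond the scatter), ends at the limit of > 100000 nM in this assay, at which 2 of the 3 values shown sit. Compound 4 `CSc1ncnc2c1c(-c1cccs1)cn2[C@@H]1O[C@H](CO)[C@@H](O)[C@H]1O` differs from compound 3 by methylsulfanyl in place of methylamino on an aromatic carbon. Among the measured compounds shown here, no measured step covers this change; compound 1 carries the same methylsulfanyl and reaches only the limit. Compound 4 is therefore expected near the limit, with a step of a number no higher from compound 3 to compound 4 (the limit leaves the size open). Compound 4 is estimated at 100000 nM, between 40000 nM and 300000 nM.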

Compound 4, half-maximal inhibitory concentration: > 100000 nM
Compound 4 gave a limit, no number; the forecaster's own chance of this, stated with the estimate: 60%; the middle value sits exactly at the limit.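

In this assay, methylsulfanyl in place of methoxy on this aromatic carbon gives an at least 2.3-fold higher number from compound 2 to compound 4 (0.36 log units; beyond the scatter), which matches what methylamino gave at the same place. Methoxy is now the only group here that yields a number, while methylsulfanyl and methylamino both end at a limit. The steps from methylamino to methylsulfanyl and from phenyl to thiophen-2-yl cannot be read, since both ends of each are limits: the limit of > 100000 nM in this assay, at which 3 of the 4 values shown sit.

Going by these compounds, how far methylsulfanyl and methylamino lie apart stays open. Also open, on these data alone, is whether a longer chain such as ethoxy, or a plain amine, on this carbon would give a number.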